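The compounds below may be only part of what the source reports. "The series", "measured", "known", "first", "only" and "open" are said of these compounds alone.

In a functional assay on HepG2 cells (Homo sapiens) for inhibition, read by MTT assay, with a stated time of 72 h (a lower number here means a stronger inhibitor, a higher number a weaker inhibitor), compound 2, whose structure is `COc1ccc(-c2cc(C(=O)N3CCC4(CC3)CC(=O)c3nn(C(C)(C)C)cc3O4)c3ccccc3n2)cc1OC`, gives 1560 nM. Within the data shown here, that is the higher of the two numbers measured so far, but only by a small margin: compound 1, with structure `CC(C)(C)n1cc2c(n1)C(=O)CC1(CCN(C(=O)c3cc(-c4ccc(Br)cc4)nc4ccccc34)CC1)O2`, gives 820 nM in this assay, and the step of a 1.9-fold higher number from compound 1 to compound 2 (0.28 log units; within the scatter) lies within the scatter, so the two compounds cannot be told apart on these data. Compound 3, with structure `CCOc1cc(C(=O)N2CCC3(CC2)CC(=O)c2nn(C(C)(C)C)cc2O3)c2ccccc2n1`, has not yet been measured in this assay. It differs from compound 2 as follows: ethoxy in place of 3,4-dimethoxyphenyl on an aromatic carbon. Among the measured compounds shown here, the only measured step, from compound 1 to compound 2, exchanged one six-membered aromatic ring of carbon only for another and left the number essentially unchanged; no measured step removes that ring altogether, as the change to compound 3 does. The expectation therefore rests on the two values alone, and a change of this size could move the number in either direction. Compound 3 is estimated at 3000 nM, with a range from 800 nM to 12000 nM, which means an expected step of a 1.9-fold higher number from compound 2 to compound 3 (0.28 log units; within the scatter).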

Compound 3, half-maximal inhibitory concentration: > 10000 nM
Compound 3 ended at the assay's limit; the forecaster's own chance of this, stated with the estimate: 20%; at least 3.3-fold (0.52 log units) between middle value and limit.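

In this assay the result for compound 3 is a limit of the assay and not a number: the limit of > 10000 nM in this assay, at which 1 of the 3 values shown sits.

On the aromatic carbon next to the ring nitrogen, ethoxy in place of 3,4-dimethoxyphenyl gives an at least 6.4-fold higher number from compound 2 to compound 3 (0.80 log units; beyond the scatter), and ethoxy in place of 4-bromophenyl gives an at least 12-fold higher number from compound 1 to compound 3 (1.08 log units; beyond the scatter). Where the earlier step, a 1.9-fold higher number from compound 1 to compound 2 (0.28 log units; within the scatter), only exchanged one six-membered aromatic ring of carbon only for another, these two steps remove that ring, and they are the first changes among the compounds shown to lie beyond the scatter, so the position is not indifferent to every change.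

The compounds shown cannot separate the loss of the ring itself from the drop in heavy atoms, as both change together in compound 3. Going by these compounds, it also stays open whether a saturated ring such as cyclohexyl, a benzyl group or an amine on this carbon would give a number close to that of compound 2 or would also reach the limit of this assay.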